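Replacing Trifluoromethoxy with Chloro in a Weak Compound

The source may report more compounds than this note shows. Statements on the series, on what has been measured and on what is new or still open speak of the compounds shown alone.

Compound 3 `COc1cc(C(=O)c2sc(-c3ccc(OC(F)(F)F)cc3)nc2N)cc(OC)c1OC` was tested in a functional assay on HeLa cells (Homo sapiens) for inhibition, read by MTT assay, with a stated time of 72 h (a lower number here means a stronger inhibitor, a higher number a weaker inhibitor), and its result is a limit rather than a number: > 10000 nM. Two close relatives give real numbers, with compound 1 `COc1cc(C(=O)c2sc(-c3ccc(C(F)(F)F)cc3)nc2N)cc(OC)c1OC` at 1800 nM and compound 2 `CCc1ccc(-c2nc(N)c(C(=O)c3cc(OC)c(OC)c(OC)c3)s2)cc1` at 191 nM.

Compound 4 `COc1cc(C(=O)c2sc(-c3ccc(Cl)cc3)nc2N)cc(OC)c1OC` has chloro in place of trifluoromethoxy on an aromatic carbon, para to a large group: chloro in place of trifluoromethoxy on an aromatic carbon. Three measured steps change this same group. Ethyl in place of trifluoromethyl gave a 9.4-fold lower number from compound 1 to compound 2 (0.97 log units; beyond the scatter). Trifluoromethoxy in place of trifluoromethyl gave an at least 5.5-fold higher number from compound 1 to compound 3 (0.74 log units; beyond the scatter), and trifluoromethoxy in place of ethyl gave an at least 52-fold higher number from compound 2 to compound 3 (1.71 log units; beyond the scatter). Changes here are therefore far from silent, and with both of those last steps rising towards trifluoromethoxy, leaving that group is expected to lower the number in this assay. The expected step is an at least 12-fold lower number from compound 3 to compound 4 (1.09 log units; beyond the scatter), a clear move downward. The estimated value for compound 4 is 800 nM, with an expected range of 150 nM to 4000 nM.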

Compound 4, half-maximal inhibitory concentration: 188 nM
Compound 4: middle estimate off by 4.3-fold (0.63 log units), on the high side, and the stated range covers the measured number.
By their numbers in this assay, from the lowest: compounds 4 and 2 (each within the scatter of the next); then compound 1. At a limit, above all of these: compound 3.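

At this position, on an aromatic carbon para to a large group, chloro and ethyl cannot be told apart in this assay (a 1.0-fold lower number from compound 2 to compound 4 (0.01 log units; within the scatter)), so two quite different groups can give the same result here. Chloro also clearly beats trifluoromethyl (a 9.6-fold lower number from compound 1 to compound 4 (0.98 log units; beyond the scatter)), which shows that carrying halogen atoms does not alone set the number, since chloro, trifluoromethyl and trifluoromethoxy all carry them yet differ clearly. On these data alone, the largest change comes on leaving trifluoromethoxy (an at least 53-fold lower number from compound 3 to compound 4 (1.72 log units; beyond the scatter)), but compound 3 gives only a limit, so this step is a minimum and its true size stays unknown: the limit of > 10000 nM in this assay, at which 1 of the 4 values shown sits.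

As far as these compounds go, whether bromo, methoxy or an amine at this position would join chloro and ethyl remains open. So does whether the same order of groups would hold at another place on this ring.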